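From Propyl to Piperidinylamino on the Carbonyl Carbon

The source may hold more compounds than are shown below. What is called first, only, known or untested is meant among the compounds shown, and "the series" means these compounds.

compound 1 `CCOC(=O)c1cc(-c2ccc(Cl)cc2)n(-c2ccc(S(N)(=O)=O)cc2)n1`: 53300 nM
compound 2 `CCCC(=O)c1cc(-c2ccc(S(N)(=O)=O)cc2)n(-c2ccc(Cl)cc2)n1`: 25800 nM
compound 3 `CCC(=O)c1cc(-c2ccc(S(N)(=O)=O)cc2)n(-c2ccc(OC)cc2)n1`: 64300 nM

In a physicochemical assay for solubility, read by HPLC, in phosphate buffer, measured as kinetic solubility, at pH 7.4 (a lower number here means a less soluble compound, a higher number a more soluble compound), compound 2 stands at the lowest of the three numbers; compound 1 lies one step higher, beyond the scatter, and compound 3 lies further still, also beyond the scatter. Compound 4 `NS(=O)(=O)c1ccc(-c2cc(C(=O)NN3CCCCC3)nn2-c2ccc(Cl)cc2)cc1` has not yet been measured. It differs from compound 2 in a single place: (piperidin-1-yl)amino in place of propyl on a carbonyl carbon. For the measured compounds named here, no pair of measured compounds shows this same change, so there is no measured step to lean on. A step upward of modest size is expected in this assay, beyond the scatter, as a 2.1-fold higher number from compound 2 to compound 4 (0.33 log units; beyond the scatter). Compound 4 is therefore estimated at 55000 nM, with a range from 22000 nM to 140000 nM.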

Compound 4, solubility: 53700 nM
Compound 4: the middle estimate sits 1.0-fold (0.01 log units) above what was measured, and the stated range covers the measured number.
By their numbers in this assay, from the lowest: compound 2; then compounds 1, 4 and 3 (each within the scatter of the next).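

In this assay, for the compounds shown here, (piperidin-1-yl)amino in place of propyl on a carbonyl carbon gives a 2.1-fold higher number from compound 2 to compound 4 (0.32 log units; beyond the scatter), the only step that can be read at this position. The change brings in a ring, nitrogen and a hydrogen-bond donor together, and this single step does not separate them. No measurement shown accounts for the step. On these data alone, it remains open whether cyclohexyl on the same carbonyl carbon would give a step of similar size. As far as these compounds go, a simple amine such as dimethylamino in that place is equally open.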